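Swapping the Ring on the Carbonyl Carbon of a Quinoline Chalcone

The source may hold more compounds than are shown below. What is called first, only, known or untested is meant among the compounds shown, and "the series" means these compounds.

Of the compounds shown here, three sharing one core have been tested in a functional assay on SK-BR-3 cells (Homo sapiens) for antiproliferative activity, read by XTT assay, with a stated time of 72 h; on this read-out lower numbers stand for stronger inhibition and higher numbers for weaker inhibition. Compound 1 `COc1ccc(C(=O)/C=C/c2nc3ccccc3cc2-c2ccc(OC)cc2)cc1` gives 9280 nM. Compound 2 `COc1ccc(-c2cc3ccccc3nc2/C=C/C(=O)c2ccccn2)cc1` gives 370 nM, and compound 3 `COc1ccc(-c2cc3ccccc3nc2/C=C/C(=O)c2ccsc2)cc1` gives 660 nM. Compound 3 stands second highest of the three numbers; its values and those of compound 2 lie within the usual scatter of each other, while a 14-fold lower number from compound 1 to compound 3 (1.15 log units; beyond the scatter) and a 25-fold lower number from compound 1 to compound 2 (1.40 log units; beyond the scatter) are both large.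

Compound 4 `COc1ccc(-c2cc3ccccc3nc2/C=C/C(=O)c2c[nH]c3ccccc23)cc1` differs from compound 3 by 1H-indol-3-yl in place of thiophen-3-yl on a carbonyl carbon. All three measured steps concern the same position, the group on the carbonyl carbon. They show that changing that group can move the number strongly, as in a 14-fold lower number from compound 1 to compound 3 (1.15 log units; beyond the scatter), or hardly at all, as in a 1.8-fold higher number from compound 2 to compound 3 (0.25 log units; within the scatter). Among the compounds with values here, no measured compound carries 1H-indol-3-yl or any group built like it, so the direction of this step is open. The balanced reading is that compound 4 is expected to stay close to compound 3, giving a 1.3-fold lower number from compound 3 to compound 4 (0.12 log units; within the scatter) in this assay, with a wide allowance either way.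

Compound 4 is therefore estimated at 500 nM, with a likely range from 150 nM to 2500 nM.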

Compound 4, half-maximal inhibitory concentration: 3450 nM
For compound 4 the middle estimate is 6.9-fold (0.84 log units) below the measured one; the measured number lies above the stated range.
By their numbers in this assay, from the lowest: compounds 2 and 3 (each within the scatter of the next); then compound 4; then compound 1.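

The two-ring 1H-indol-3-yl does not match the single rings before it: in this assay there is a 5.2-fold higher number from compound 3 to compound 4 (0.72 log units; beyond the scatter) and a 9.3-fold higher number from compound 2 to compound 4 (0.97 log units; beyond the scatter), so the closeness of thiophen-3-yl and pyridin-2-yl does not extend to every ring on this carbonyl carbon. The new group still gives a lower number than 4-methoxyphenyl, with a 2.7-fold lower number from compound 1 to compound 4 (0.43 log units; beyond the scatter), which places compound 4 between the other compounds rather than beside either end. Nothing available explains this order.

This one change adds a second ring and a hydrogen-bond donor together, so the compounds shown cannot separate the two. From the compounds shown here alone, a group such as 1-methyl-1H-indol-3-yl or pyrrol-3-yl would pull them apart, and how a non-ring group, such as an amine or a short alkyl chain, behaves here remains open.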